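The source may report more compounds than this note shows. Statements on the series, on what has been measured and on what is new or still open speak of the compounds shown alone.

Series notes, cytotoxicity. Compound 1 `Cn1c(-c2ccc(NC(=O)CN3CCCC3)cc2)nc2cc(C(F)(F)F)ccc21` in an ADME assay on MDBK cells (Bos taurus) for cytotoxicity, read by MTT assay, with a stated time of 96 h (a higher number here means that more compound is tolerated, a lower number that less compound is tolerated), gives 65000 nM. Compound 2 `O=C(CN1CCCC1)Nc1ccc(-c2nc3cc(C(F)(F)F)ccc3[nH]2)cc1` in this assay gives 15000 nM; the change hydrogen in place of methyl on an aromatic nitrogen made the step of a 4.3-fold lower number from compound 1 to compound 2 (0.64 log units; beyond the scatter). Compound 3 `Cn1c(-c2ccc(NC(=O)CN3CCCCC3)cc2)nc2cc(C(F)(F)F)ccc21` in this assay gives 100000 nM; its core differs from that of compound 1 by piperidin-1-yl in place of pyrrolidin-1-yl on a saturated chain carbon bound to a carbonyl carbon, and that change made the step of a 1.5-fold higher number from compound 1 to compound 3 (0.19 log units; within the scatter), so compound 1 and compound 3 are not told apart here.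

Compound 4 `O=C(CN1CCCCC1)Nc1ccc(-c2nc3cc(C(F)(F)F)ccc3[nH]2)cc1` is not yet measured. Within the data shown here, it differs from compound 3 by hydrogen in place of methyl on an aromatic nitrogen, the same change as the one from compound 1 to compound 2, at the same place in the same words. Among the measured compounds shown here, that earlier change lowered the number beyond the scatter, and the only other step seen was within the scatter, so the expectation for compound 4 rests on the step of a 4.3-fold lower number from compound 1 to compound 2 (0.64 log units; beyond the scatter) alone. The step from compound 3 to compound 4 is expected to be a 4.3-fold lower number from compound 3 to compound 4 (0.64 log units; beyond the scatter), of similar size to the earlier one. Compound 4 is therefore estimated at 23000 nM, with a range from 10000 nM to 55000 nM.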

Compound 4, half-maximal cytotoxic concentration: 6000 nM
Estimate against measurement, compound 4: 3.8-fold (0.58 log units) above, and the stated range ends above it.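

In this assay, hydrogen in place of methyl on the aromatic nitrogen lowers the number on both cores, but the size does not carry over, and a 17-fold lower number from compound 3 to compound 4 (1.22 log units; beyond the scatter) is a much larger step than the one seen first: the same change on two cores in this assay, a 4.3-fold lower number (0.64 log units; beyond the scatter) from compound 1 to compound 2 and a 17-fold lower number (1.22 log units; beyond the scatter) from compound 3 to compound 4, 3.8-fold (0.59 log units) apart, beyond the scatter of two such steps. The change of piperidin-1-yl for pyrrolidin-1-yl does not carry over either, since compound 1 and compound 3 are not told apart, whereas on the cores bearing hydrogen there is a 2.5-fold lower number from compound 2 to compound 4 (0.40 log units; beyond the scatter): the same change on two cores in this assay, a 1.5-fold higher number (0.19 log units; within the scatter) from compound 1 to compound 3 and a 2.5-fold lower number (0.40 log units; beyond the scatter) from compound 2 to compound 4, 3.8-fold (0.59 log units) apart, beyond the scatter of two such steps. The two changes therefore do not add up in these four compounds, so a step measured on one core is a poor guide to its size on the other, but this set gives no reason for the mismatch and does not show that it extends beyond these compounds.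

From the compounds shown here alone, it remains open whether the same mismatch appears with a morpholine or an open-chain dimethylamine in place of the saturated ring. An ethyl group on the aromatic nitrogen is likewise untested here.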